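Working notes: 4-ethylphenyl to 3,4-dimethylphenyl on the amine

The source may hold more compounds than are shown below. What is called first, only, known or untested is meant among the compounds shown, and "the series" means these compounds.

- compound 1 `O=C1C(Nc2ccccc2)=CC(=O)c2c1nc1n2[C@H]2OC[C@@H](O)[C@H]2OC1`: > 4000 nM, a limit
- compound 2 `CCc1ccc(NC2=CC(=O)c3c(nc4n3[C@H]3OC[C@@H](O)[C@H]3OC4)C2=O)cc1`: 8990 nM
- compound 3 `Cc1ccc(NC2=CC(=O)c3c(nc4n3[C@H]3OC[C@@H](O)[C@H]3OC4)C2=O)cc1C`: not yet measured

All values come from a functional assay on MCF7 cells (Homo sapiens) for inhibition, read by sulforhodamine B assay; on this read-out higher numbers stand for weaker inhibition and lower numbers for stronger inhibition. Within the data shown here, compound 2 gives 8990 nM, the only true number in the set. Compound 1 stands at the limit of > 4000 nM in this assay, at which 1 of the 2 values shown sits, and this is a limit, not a number. Among the measured compounds shown here, the one measured step is a step that the limit leaves unreadable from compound 1 to compound 2, with ethyl in place of hydrogen on an aromatic carbon, so it offers no size to carry forward.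

Compound 3 changes the group on the amine nitrogen: 3,4-dimethylphenyl in place of 4-ethylphenyl on an amine nitrogen. The two have the same atoms, joined differently. For the measured compounds named here, no readable step bears on this change, so the only anchor is compound 2 at 8990 nM, and no shift beyond the scatter is expected in this assay. The expected step is a 1.1-fold lower number from compound 2 to compound 3 (0.05 log units; within the scatter). For compound 3 the estimated value is 8000 nM, with an expected range of 3000 nM to 20000 nM.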

Compound 3, half-maximal inhibitory concentration: 4950 nM
For compound 3 the middle estimate is 1.6-fold (0.21 log units) above the measured one; the measured number falls inside the stated range.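

In this assay, among these compounds, the exchange of 4-ethylphenyl for 3,4-dimethylphenyl on the amine nitrogen gives the first readable step: a 1.8-fold lower number from compound 2 to compound 3 (0.26 log units; within the scatter). With the same atoms joined differently, the two groups are not told apart at this position in this assay. The steps from compound 1 to compound 2 and to compound 3 cannot be read, as compound 1 gives a limit and not a number: the limit of > 4000 nM in this assay, at which 1 of the 3 values shown sits.

The compounds shown leave open whether a longer chain such as butyl, or a group of another kind on the aromatic ring such as a carboxylic acid or an amine, moves the number beyond the scatter. They also leave open how either alkyl-bearing ring compares in size of step with the plain phenyl of compound 1.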